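Cyclohexylmethyl ether replacing furylmethyl ether in the series

This account rests on a few compounds, and the source may have more. Where it says the series, first, only, none or still open, it means among the compounds named here.

For the measured compounds named here, compound 2 `C[C@@H](NCc1ccc(OCc2ccco2)cc1)C(N)=O` gives 116 mg/kg in a functional assay on the whole organism with Mus musculus as the target (on this read-out lower numbers stand for an effect already at smaller amounts and higher numbers for an effect only at larger amounts of compound), the highest of the two numbers so far; the nearest is compound 1 `C[C@@H](NCc1ccc(OCCc2ccccc2)cc1)C(N)=O` with 24.9 mg/kg, and the step of a 4.7-fold higher number from compound 1 to compound 2 (0.67 log units; beyond the scatter) is the only one measured. Compound 3 `C[C@@H](NCc1ccc(OCC2CCCCC2)cc1)C(N)=O` carries cyclohexyl in place of furan-2-yl on a saturated chain carbon bound to an oxygen on an aromatic ring. Going by the values given here, no measured step covers this exact change. Because a 4.7-fold higher number from compound 1 to compound 2 (0.67 log units; beyond the scatter) shows that exchanging the group at this place moves the number beyond the scatter, and the entering ring is a six-membered non-aromatic ring of carbon only, without the acceptor of furan-2-yl, a move back toward compound 1 is expected, a 3.3-fold lower number from compound 2 to compound 3 (0.52 log units; beyond the scatter). For compound 3 the expected value is 35 mg/kg, between 12 mg/kg and 100 mg/kg.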

Compound 3, dose for half-maximal effect: 131 mg/kg
Compound 3: middle estimate off by 3.7-fold (0.57 log units), on the low side; the measured number lies above the stated range.
By their numbers in this assay, from the lowest: compound 1; then compounds 2 and 3 (each within the scatter of the next).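

In this assay, cyclohexyl in place of furan-2-yl on a saturated chain carbon bound to an oxygen on an aromatic ring gives no separable change (a 1.1-fold higher number from compound 2 to compound 3 (0.05 log units; within the scatter)), so the aromatic five-membered ring with its hydrogen-bond acceptor and the all-carbon six-membered ring read alike here. Compound 1 stays apart from this pair (a 5.3-fold higher number from compound 1 to compound 3 (0.72 log units; beyond the scatter)). No evidence bears on the reason for this.

Still open, as far as these compounds go, is whether cyclohexyl on a longer chain would reach the number of compound 1. An amine or a carboxylic acid on the ring at this place also remains untested in the compounds shown.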